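Removing the Aminobutyl Side Chain: Expected Effect on Paw Edema

This account rests on a few compounds, and the source may have more. Where it says the series, first, only, none or still open, it means among the compounds named here.

Two related compounds have been tested in a functional assay on the whole organism (strain Wistar) for inhibition, with Rattus norvegicus as the target, read by paw edema, with stated times of 1 h and 24 h, at a dose of 10 mg/kg by the intraperitoneal route; a higher number here means more inhibition at the dose given (going by the name of the read-out), a lower number less inhibition. Compound 1, `Cc1ncc([N+](=O)[O-])n1CCOC(=O)c1cc(NC(=O)C(C)NC(=O)OCc2ccccc2)ccc1O`, gives 0% in this assay. Compound 2, `Cc1ncc([N+](=O)[O-])n1CCOC(=O)c1cc(NC(=O)[C@H](CCCCN)NC(=O)OCc2ccccc2)ccc1O`, gives 23.4%. Compound 2 thus holds the higher of the two measured numbers, and its distance from compound 1 lies beyond the usual scatter of repeated measurements. Compound 3, `Cc1ncc([N+](=O)[O-])n1CCOC(=O)c1cc(NC(=O)CNC(=O)OCc2ccccc2)ccc1O`, shares the same core but differs from compound 2 in one place: hydrogen in place of 4-aminobutyl on a saturated chain carbon bound to an amide-type nitrogen and a carbonyl carbon. No measured pair differs in exactly this way, so the size of this step cannot be read from the data, and no cause for the gap between compound 1 and compound 2 is known. Because compound 1 gives 0% while lacking the 4-aminobutyl group, compound 3, which also lacks it, is expected to sit nearer compound 1 than compound 2. The step of a number 18.4 percentage points lower from compound 2 to compound 3 (beyond the scatter) is therefore expected to be a drop beyond the scatter. Compound 3 is estimated at 5%, with a range from 0% to 20%.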

Compound 3, a percentage reported as inhibition, in the whole organism at one dose (the size of the read-out at that dose, not a potency): 17.1%
Estimate against measurement, compound 3: 12.1 percentage points below; measured number inside the range.
By their numbers in this assay, from the lowest: compound 1; then compounds 3 and 2 (each within the scatter of the next).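

In this assay, putting hydrogen in place of 4-aminobutyl on the saturated chain carbon gives a number 6.3 percentage points lower from compound 2 to compound 3 (within the scatter) and so shows that the inhibition seen at this dose does not depend on the 4-aminobutyl group. The same carbon still responds to a change, since hydrogen in place of methyl gives a number 17.1 percentage points higher from compound 1 to compound 3 (beyond the scatter) and leaves the methyl-bearing compound 1 as the one that stands apart from the other two. Nothing available explains why replacing methyl matters here while replacing the longer chain does not.

Going by these compounds, it remains open whether the amine of the 4-aminobutyl group plays any part: a plain butyl chain, or a chain ending in a carboxylic acid, on this carbon would help separate the length of the chain from the group at its end. An ethyl group on the same carbon would help show whether the low number of compound 1 belongs to methyl alone or extends to other short alkyl groups.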